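Aryl replacement on the shared core: cytotoxicity notes

The source may hold more compounds than are shown below. What is called first, only, known or untested is meant among the compounds shown, and "the series" means these compounds.

Measured so far:
compound 1 `Cc1ccc(C(O)c2cc(Cl)ccc2OCC(=O)Nc2ccc(S(N)(=O)=O)cc2C)cc1`, 38700 nM
compound 2 `Cc1cc(S(N)(=O)=O)ccc1NC(=O)COc1ccc(Cl)cc1C(O)c1cccc([N+](=O)[O-])c1`, 36900 nM
compound 3 `Cc1cc(S(N)(=O)=O)ccc1NC(=O)COc1ccc(Cl)cc1C(O)c1cc(Cl)cc(Br)c1`, 22900 nM

In an ADME assay on C8166 cells (Homo sapiens) for cytotoxicity, read by MTT assay (a lower number here means that less compound is tolerated, a higher number that more compound is tolerated), compound 1 gives the highest of the three numbers, yet its nearest neighbour compound 2 lies at a 1.0-fold lower number from compound 1 to compound 2 (0.02 log units; within the scatter) and the furthest, compound 3, at a 1.7-fold lower number from compound 1 to compound 3 (0.23 log units; within the scatter), so no ordering is claimed. Compound 4 `Cc1cc(S(N)(=O)=O)ccc1NC(=O)COc1ccc(Cl)cc1C(O)c1cc(Cl)cc(C#N)c1` carries 3-chloro-5-cyanophenyl in place of 4-methylphenyl on a saturated chain carbon bound to an aromatic carbon and an oxygen on a saturated carbon. The bearing steps are a 1.0-fold lower number from compound 1 to compound 2 (0.02 log units; within the scatter), a 1.7-fold lower number from compound 1 to compound 3 (0.23 log units; within the scatter) and a 1.6-fold lower number from compound 2 to compound 3 (0.21 log units; within the scatter), all within the scatter, so the aryl on this carbon has so far left the tolerated concentration unchanged. Compound 4 is expected to behave likewise, with a 1.3-fold lower number from compound 1 to compound 4 (0.11 log units; within the scatter), a step not beyond the scatter. Compound 4 is therefore estimated at 30000 nM, range 15000 nM to 60000 nM.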

Compound 4, half-maximal cytotoxic concentration: 31600 nM
Compound 4: middle estimate off by 1.1-fold (0.02 log units), on the low side; measured number inside the range.
By their numbers in this assay, from the lowest: compounds 3, 4, 2 and 1 (each within the scatter of the next).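

In this assay, going by these compounds alone, 3-chloro-5-cyanophenyl stays level with 4-methylphenyl (a 1.2-fold lower number from compound 1 to compound 4 (0.09 log units; within the scatter)) and with 3-nitrophenyl (a 1.2-fold lower number from compound 2 to compound 4 (0.07 log units; within the scatter)), and the single exchange of cyano in place of bromo on an aromatic carbon also leaves the number level (a 1.4-fold higher number from compound 3 to compound 4 (0.14 log units; within the scatter)). The flat picture on this saturated chain carbon therefore extends to an aryl bearing a nitrile. No available evidence bears on this result. On these data alone, all four compounds keep an aryl on this carbon, so the effect of an amine, a carboxylic acid or a longer alkyl chain there remains open.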